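This account rests on a few compounds, and the source may have more. Where it says the series, first, only, none or still open, it means among the compounds named here.

Among the measured compounds shown here, in a functional assay on a cell-free system (Platelet, plasma, Oryctolagus cuniculus) for inhibition, with a stated time of 5 min, at 37 degrees C (on this read-out higher numbers stand for weaker inhibition and lower numbers for stronger inhibition), compound 3 `CCOC(=O)/C=C/c1ccc(OC)c(OC(=O)c2nc(C)c(C)nc2C)c1` gives 143000 nM, the highest of the three numbers so far. Compound 1 `COc1cc(/C=C/C(=O)O)ccc1OC(=O)c1nc(C)c(C)nc1C` gives 44600 nM and compound 2 `COc1ccc(/C=C/C(=O)O)cc1OC(=O)c1nc(C)c(C)nc1C` gives 41800 nM. For the measured compounds named here, the only measured step, a 3.4-fold higher number from compound 2 to compound 3 (0.53 log units; beyond the scatter), turns the acid into the ethyl ester, which compound 4 `CCOC(=O)/C=C/c1cccc(OC(=O)c2nc(C)c(C)nc2C)c1` keeps. Compound 4 differs from compound 3 by hydrogen in place of methoxy on an aromatic carbon, with hydrogen in place of methoxy on an aromatic carbon. Going by the values given here, no measured step covers this change, so that earlier step gives no guide to its size, and no step beyond the scatter is expected in this assay, in either direction. The expected move is only a 1.1-fold lower number from compound 3 to compound 4 (0.04 log units; within the scatter). For compound 4 the estimate is 130000 nM, with an expected range from 50000 nM to 300000 nM.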

Compound 4, half-maximal inhibitory concentration: 35800 nM
Beside the measured number, compound 4's estimate is 3.6-fold (0.56 log units) above it, and the stated range ends above it.
By their numbers in this assay, from the lowest: compounds 4, 2 and 1 (each within the scatter of the next); then compound 3.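

Hydrogen in place of methoxy on this aromatic carbon, para to the 2-(ethoxycarbonyl)ethenyl group, is not a silent change: it brings a 4.0-fold lower number from compound 3 to compound 4 (0.60 log units; beyond the scatter) in this assay. The earlier compounds shown here all carry a methoxy, so they could not show that, within this ethyl ester pair, the methoxy goes with the higher number. Nothing given here accounts for the step. Going by these compounds, whether a hydroxyl or a chlorine on this carbon would keep the lower number remains open, as does whether the free acid would answer this change in the same way.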